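The source may hold more compounds than are shown below. What is called first, only, known or untested is meant among the compounds shown, and "the series" means these compounds.

Of the compounds shown here, three have been measured so far in a functional assay on BGC-823 cells (Homo sapiens) for antiproliferative activity, read by MTT assay, with a stated time of 48 h (a lower number here means a stronger inhibitor, a higher number a weaker inhibitor), and a fourth awaits its turn. Compound 1 `Fc1ccccc1CSc1nnc(-c2cnccn2)o1` gives 18200 nM in this assay. Compound 2 `Clc1ccccc1CSc1nnc(-c2cnccn2)o1` differs from compound 1 in a single place, namely (chloro in place of fluoro on an aromatic carbon), and in this assay compound 2 gives 27700 nM. That single change made a step of a 1.5-fold higher number from compound 1 to compound 2 (0.18 log units; within the scatter), so the two values cannot be told apart with confidence. Compound 3 `Fc1ccccc1CSc1nnc(-c2cnccn2)s1` carries the same fluoro-bearing side group as compound 1 but on a different core; the difference between the two cores is not broken down here. In this assay compound 3 gives 18400 nM, a number that sits with those of compound 1 and compound 2 inside the usual scatter, so no order among the three can be read from these data.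

Compound 4 `Clc1ccccc1CSc1nnc(-c2cnccn2)s1` is the one not yet measured. It differs from compound 3 by chloro in place of fluoro on an aromatic carbon, which is the same change as that from compound 1 to compound 2, made at a place described in the same words. Among the measured compounds shown here, the expected step is a 1.5-fold higher number from compound 3 to compound 4 (0.17 log units; within the scatter), an expectation that rests on the one earlier instance of this change, the step of a 1.5-fold higher number from compound 1 to compound 2 (0.18 log units; within the scatter), and on the fact that compound 3 starts from a value close to that of compound 1. Compound 4 is therefore estimated at 27000 nM, with a likely range from 12000 nM to 60000 nM, to be checked against the measurement.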

Compound 4, half-maximal inhibitory concentration: 20300 nM
Compound 4: the middle estimate sits 1.3-fold (0.12 log units) above what was measured; measured number inside the range.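

Putting chloro in place of fluoro on the core of compound 3 gives, in this assay, a step of a 1.1-fold higher number from compound 3 to compound 4 (0.04 log units; within the scatter), so on this core, as on the core of compound 1, the two values cannot be told apart. The two steps also agree with each other: the same change on two cores in this assay, a 1.5-fold higher number (0.18 log units; within the scatter) from compound 1 to compound 2 and a 1.1-fold higher number (0.04 log units; within the scatter) from compound 3 to compound 4, 1.4-fold (0.14 log units) apart, within the scatter of two such steps. This shows that the swap left no readable mark on either of these two cores, but it does not show that an effect of this change carries from one core to the other, as two steps inside the scatter give no clear effect to follow, and two cores are too few to support a rule for the series.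

As far as these compounds go, only fluoro and chloro appear here, on an aromatic carbon of a six-membered aromatic ring of carbon only, ortho to a large group, so what an amine, a methoxy group or a carboxylic acid would do at that place stays open. From the compounds shown here alone, it also stays open whether a change that gives a step beyond the scatter on one of these cores would give a matching step on the other.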